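Swapping methoxy for fluoro beside a sulfonamide on an anilide

The source may report more compounds than this note shows. Statements on the series, on what has been measured and on what is new or still open speak of the compounds shown alone.

Compound 3, with the structure `COc1cc(NC(=O)c2cc(C(F)(F)F)cc(C(F)(F)F)c2)ccc1NS(=O)(=O)C(F)(F)F`, was tested in an ADME assay on HEK293 cells (Homo sapiens) for cytotoxicity, read by MTT assay, with a stated time of 48 h; a higher number here means a weaker inhibitor, a lower number a stronger inhibitor. In that test compound 3 gives > 250000 nM, which is a limit of the assay and not a measured number. Two close relatives were tested in the same way. Compound 1, `CCS(=O)(=O)Nc1ccc(NC(=O)c2cc(C(F)(F)F)cc(C(F)(F)F)c2)cc1OC`, gives > 250000 nM in this assay, again a limit rather than a number. Compound 2, `COc1cc(NC(=O)c2cccc(C(F)(F)F)c2)ccc1NS(=O)(=O)C(F)(F)F`, gives > 250000 nM in this assay, also a limit. The two structural steps that connect them to compound 3 therefore cannot be sized: a step that the two limits leave unreadable from compound 1 to compound 3 and a step that the two limits leave unreadable from compound 2 to compound 3. All that can be said is the limit of > 250000 nM in this assay, at which 3 of the 3 values shown sit.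

Compound 4, `O=C(Nc1ccc(NS(=O)(=O)C(F)(F)F)c(F)c1)c1cc(C(F)(F)F)cc(C(F)(F)F)c1`, has not yet been measured in this assay. It differs from compound 3 by fluoro in place of methoxy on an aromatic carbon. Among the compounds with values here, no measured step touches this particular change, and the two steps that exist are unreadable, so the only guide is that every relative tested so far sits at the limit. On that basis the expected step from compound 3 to compound 4 is a number no higher from compound 3 to compound 4 (the limit leaves the size open), meaning no shift beyond the scatter. Compound 4 is therefore estimated at 250000 nM, with a range from 100000 nM to 600000 nM, and most likely it will again be reported only as a limit.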

Compound 4, half-maximal inhibitory concentration: 164000 nM
Compound 4: middle estimate off by 1.5-fold (0.18 log units), on the high side, within the range that was stated.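

Fluoro in place of methoxy, ortho to a ((trifluoromethyl)sulfonyl)amino group, gives the first true number in this set: in this assay, the change produces an at least 1.5-fold lower number from compound 3 to compound 4 (0.18 log units; that floor lies within the scatter). This shows that a change at this one position can bring a compound of this family into the readable range of the assay, which neither the ethyl-to-trifluoromethyl change on the sulfonyl sulfur nor the added trifluoromethyl on the aromatic carbon could show, as those steps cannot be read. The result is still modest, since the true size of the step stays unknown and its floor does not clear the usual scatter, and compound 4 stands alone against a shared ceiling: the limit of > 250000 nM in this assay, at which 3 of the 4 values shown sit.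

The compounds shown leave open whether this behaviour belongs to fluoro itself, as nothing here shows how chloro, a hydroxyl, an amine or a longer chain such as ethoxy would read at the same position. They also leave open whether fluoro would give a readable number with ethyl on the sulfonyl sulfur, or with a single trifluoromethyl on the benzoyl side of the amide.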